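Amides on a Shared Core: One Change at the Far End

The compounds below may be only part of what the source reports. "The series", "measured", "known", "first", "only" and "open" are said of these compounds alone.

Measured compounds:
compound 1, `CCc1ccc(NC(=O)c2csc(Cc3c(Cl)cccc3Cl)n2)cc1`, giving 810 nM in an assay on CHO cells, read by calcium flux; on this read-out lower numbers stand for stronger inhibition and higher numbers for weaker inhibition
compound 2, `O=C(Nc1ccc(C(F)(F)F)cc1)c1csc(Cc2c(Cl)cccc2Cl)n1`, giving 140 nM in this assay

Compound 2 holds the lower of the two numbers. Among the measured compounds shown here, its nearest neighbour is compound 1, and the one measured step, a 5.8-fold lower number from compound 1 to compound 2 (0.76 log units; beyond the scatter), comes from trifluoromethyl in place of ethyl on an aromatic carbon of the anilide part.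

Compound 3, `O=C(Nc1ccc(C(F)(F)F)cc1)c1csc(Nc2ccccc2Cl)n1`, differs from compound 2 by (2-chlorophenyl)amino in place of 2,6-dichlorobenzyl on an aromatic carbon. This change sits on an aromatic carbon of the shared core, away from the anilide part altered in the measured step, so that step gives no guide to it. With nothing measured at this position, the expected step of a 2.1-fold higher number from compound 2 to compound 3 (0.33 log units; beyond the scatter) is set close to no change, but with a wide range in both directions. In this assay compound 3 is estimated at 300 nM, between 60 nM and 1500 nM.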

Compound 3, half-maximal inhibitory concentration: 1750 nM
The estimate for compound 3 lay 5.8-fold (0.77 log units) below the measured number; the whole stated range lies below it.
By their numbers in this assay, from the lowest: compound 2; then compound 1; then compound 3.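

The position on the shared core that carries the large group is clearly not neutral in this assay: with the trifluoromethyl anilide held fixed, (2-chlorophenyl)amino in place of 2,6-dichlorobenzyl gives a 13-fold higher number from compound 2 to compound 3 (1.10 log units; beyond the scatter), a large step and a move towards weaker inhibition. This single change alters several things at once, since the entering group brings a nitrogen, with one hydrogen-bond donor and one acceptor, and carries one chlorine where the leaving group carries two. Nothing available explains the loss or ties it to any one of these differences.

Going by these compounds, what a 2-chlorobenzyl group or a (2,6-dichlorophenyl)amino group would give here stays open, and with it which part of the change carries the step. Also open, on these data alone, is whether the step would be the same size with ethyl on the anilide part.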